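The compounds below may be only part of what the source reports. "The series", "measured", "known", "first", "only" and "open" are said of these compounds alone.

Measured compounds:
compound 1, `O[C@H](c1ccccn1)[C@]1(c2ccc(C(F)(F)F)cc2)C[C@@H](O)C1`, gives 50 mL/min/kg in an ADME assay on liver for metabolic stability, with Liver microsome (Rattus norvegicus) as the target, read by LC-MS, using microsomes, with a stated time of 5 h; on this read-out lower numbers stand for slow clearance and higher numbers for fast clearance
compound 2, `O[C@H](c1ccccn1)[C@]1(c2cccc(C(F)(F)F)c2)C[C@H](O)C1`, gives 183 mL/min/kg in this assay

Compound 2 stands at the higher of the two numbers, and its gap to compound 1 lies beyond the scatter. Compound 3, `O[C@H](c1ccccn1)[C@]1(c2cccc(OC(F)(F)F)c2)C[C@H](O)C1`, differs from compound 2 by trifluoromethoxy in place of trifluoromethyl on an aromatic carbon. For the measured compounds named here, no measured pair shows this change, so nothing here tells how large a step to expect. The step of a 1.2-fold lower number from compound 2 to compound 3 (0.09 log units; within the scatter) is therefore expected to stay within the scatter, with no clear direction. Compound 3 is expected to give 150 mL/min/kg, with a range from 70 mL/min/kg to 320 mL/min/kg.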

Compound 3, clearance: 117 mL/min/kg
Compound 3: the middle estimate sits 1.3-fold (0.11 log units) above what was measured, and the stated range covers the measured number.
By their numbers in this assay, from the lowest: compound 1; then compounds 3 and 2 (each within the scatter of the next).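

In this assay, trifluoromethoxy in place of trifluoromethyl on this aromatic carbon, meta to a large group, gives a 1.6-fold lower number from compound 2 to compound 3 (0.19 log units; within the scatter) and so does not separate the two groups at this position. The added oxygen, counted as a hydrogen-bond acceptor, leaves the number within the scatter of compound 2 here. Nothing at hand bears on why these two groups read so closely.

Going by these compounds, whether a nitrile, an amine or a carboxylic acid on this carbon would step beyond the scatter remains open. So does whether this change would read the same on the core of compound 1.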